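A few compounds are considered here, and "the series" means these few. Any claim that something is new, unique, unknown or untested is made for them only; others in the source may bear on it.

Three compounds share one core and differ only in the group carried on the carbonyl of the piperidine nitrogen. In a functional assay on isolated protein for inhibition of Glucose-dependent insulinotropic receptor (Homo sapiens), read by HTRF and cAMP accumulation (on this read-out higher numbers stand for an effect only at larger amounts of compound and lower numbers for an effect already at smaller amounts), compound 1 `Cc1nc(S(C)(=O)=O)ccc1Oc1ncnc(OC2CCN(C(=O)OC(C)(C)C(F)(F)F)CC2)c1F` gives 6.53 nM; compound 2 `Cc1nc(S(C)(=O)=O)ccc1Oc1ncnc(OC2CCN(C(=O)O[C@@H](C)C(F)(F)F)CC2)c1F` gives 9.86 nM; and compound 3 `Cc1nc(S(C)(=O)=O)ccc1Oc1ncnc(OC2CCN(C(=O)C(C)(F)F)CC2)c1F` gives 37 nM. Compound 3 therefore stands at the highest number of the three: the step of a 5.7-fold higher number from compound 1 to compound 3 (0.75 log units; beyond the scatter) and the step of a 3.8-fold higher number from compound 2 to compound 3 (0.57 log units; beyond the scatter) both go beyond the scatter, whereas the step of a 1.5-fold higher number from compound 1 to compound 2 (0.18 log units; within the scatter) remains within it.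

Compound 4 `Cc1nc(S(C)(=O)=O)ccc1Oc1ncnc(OC2CCN(C(=O)C(C)(C)F)CC2)c1F` has not yet been measured. It differs from compound 3 by methyl in place of fluoro on a saturated chain carbon bound to a carbonyl carbon, a fluorine atom and a saturated chain carbon. Going by the values given here, no measured step exchanges a fluorine for a methyl on this carbon, so none bears on it directly. The closest comparison is the step from compound 1 to compound 2, which likewise exchanges one small group for another within the carbonyl substituent and produces no change beyond the scatter; the larger steps to compound 3 arose from a different kind of replacement, an alkoxy group giving way to a carbon chain, and do not speak to this exchange. A step of small size is thus expected, within or only slightly beyond the scatter, with no clear direction; the expected step is a 1.1-fold lower number from compound 3 to compound 4 (0.02 log units; within the scatter). Compound 4 is accordingly estimated at 35 nM in this assay, with a range from 14 nM to 85 nM.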

Compound 4, half-maximal effective concentration: 76.3 nM
Compound 4: the middle estimate sits 2.2-fold (0.34 log units) below what was measured, and the stated range covers the measured number.
By their numbers in this assay, from the lowest: compounds 1 and 2 (each within the scatter of the next); then compound 3; then compound 4.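

In this assay, going by these compounds alone, the exchange at this saturated chain carbon proves not to be neutral: with methyl in place of fluoro, the result is a 2.1-fold higher number from compound 3 to compound 4 (0.31 log units; beyond the scatter), the first step that leaves the alkoxy-versus-chain question aside and alters the chain group itself. The change also widens the distance between the 1-fluoro-1-methylethyl group and the two oxygen-linked groups, giving a 7.7-fold higher number from compound 2 to compound 4 (0.89 log units; beyond the scatter) and a 12-fold higher number from compound 1 to compound 4 (1.07 log units; beyond the scatter), so that compound 4 now carries the highest number of the four and the second of these steps is the only one in the series classed as large. Nothing available accounts for this difference between fluoro and methyl on the carbon.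

The compounds shown leave open how a hydroxyl group, a chlorine atom or a nitrile would read on this same carbon, and whether a third fluorine or a cyclopropyl ring in place of the chain would follow the same direction. They also leave open how the chain groups would compare with the oxygen-linked groups if both carried the same trifluoromethyl end.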